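A few compounds are considered here, and "the series" means these few. Any claim that something is new, unique, unknown or untested is made for them only; others in the source may bear on it.

Measured so far:
- compound 1 `Cc1ccccc1S(=O)(=O)Nc1ccc2oc(-c3ccccc3)nc2c1`: 57000 nM
- compound 2 `O=[N+]([O-])c1cc(S(=O)(=O)Nc2ccc(-c3nc4ccccc4o3)cc2)ccc1Cl`: 85000 nM

Going by the values given here, in an ADME assay on HEK293 cells (Homo sapiens) for cytotoxicity, read by resazurin assay, with a stated time of 48 h (a lower number here means that less compound is tolerated, a higher number that more compound is tolerated), compound 1 gives 57000 nM, and compound 2 gives 85000 nM; the two numbers lie within the usual scatter of each other, so compound 1 stands level with the only other measured compound.

Compound 3 `CCc1ccc(S(=O)(=O)Nc2ccc3oc(-c4ccccc4)nc3c2)cc1` differs from compound 1 in one place: 4-ethylphenyl in place of 2-methylphenyl on a sulfonyl sulfur. Among the compounds with values here, no step between measured compounds is known here, so nothing shows how much such a change matters. A step of no more than the scatter, in no particular direction, is expected for a 1.0-fold lower number from compound 1 to compound 3 (0.02 log units; within the scatter). Compound 3 is therefore estimated at 55000 nM, with a range from 20000 nM to 150000 nM.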

Compound 3, half-maximal cytotoxic concentration: 81000 nM
For compound 3 the middle estimate is 1.5-fold (0.17 log units) below the measured one; low and high end bracket the measured number.
By their numbers in this assay, from the lowest: compounds 1, 3 and 2 (each within the scatter of the next).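

In this assay the exchange of 2-methylphenyl for 4-ethylphenyl on a sulfonyl sulfur gives a 1.4-fold higher number from compound 1 to compound 3 (0.15 log units; within the scatter) and so compound 1 and compound 3 cannot be told apart. Going by these compounds alone, this is the first step known at this position, and it shows that this one exchange between carbon-only aromatic groups leaves the reading unresolved. Nothing measured here bears on the size of this step.

As far as these compounds go, whether an amine or a carboxylic acid on that phenyl ring would give a step beyond the scatter stays open. Also open, from the compounds shown here alone, is whether replacing the phenyl ring with a longer alkyl chain would do so.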